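Acetyl to methylcarbamoyl: clearance notes on the series

A few compounds are considered here, and "the series" means these few. Any claim that something is new, unique, unknown or untested is made for them only; others in the source may bear on it.

Measured in an ADME assay (liver) for metabolic stability, with Liver microsome (Rattus norvegicus) as the target, using microsomes and NADPH, with a stated time of 30 min; a lower number here means slower removal, a higher number faster removal of the compound:
- compound 1 `CC#C[C@H]1CN(S(=O)(=O)c2ccc(N)nc2)CCN1c1ccc(S(=O)(=NC)C(F)(F)F)cc1`: 257 mL.min-1.g-1
- compound 2 `CC#C[C@H]1CN(S(=O)(=O)c2ccc(N)nc2)CCN1c1ccc(C(O)(COC)C(F)(F)F)cc1`: 93 mL.min-1.g-1
- compound 3 `CC#C[C@H]1CN(S(=O)(=O)c2ccc(N)nc2)CCN1c1ccc(C(C)=O)cc1`: 249 mL.min-1.g-1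

Two steps place compound 3: a 1.0-fold lower number from compound 1 to compound 3 (0.01 log units; within the scatter), and a 2.7-fold higher number from compound 2 to compound 3 (0.43 log units; beyond the scatter). Compound 4 `CC#C[C@H]1CN(S(=O)(=O)c2ccc(N)nc2)CCN1c1ccc(C(=O)NC)cc1` is the next structure, with methylamino in place of methyl on a carbonyl carbon, that is, acetyl to methylcarbamoyl. Among the measured compounds shown here, no measured step makes this exact change. The nearest evidence is the same two steps together with a 2.8-fold lower number from compound 1 to compound 2 (0.44 log units; beyond the scatter), all of which exchange a group on an aromatic carbon, and they range from within the scatter to modest. The expected step is toward a lower number, a 1.8-fold lower number from compound 3 to compound 4 (0.25 log units; within the scatter). The estimate for compound 4 is 140 mL.min-1.g-1, with an expected range of 60 mL.min-1.g-1 to 280 mL.min-1.g-1.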

Compound 4, intrinsic clearance in microsomes: 41 mL.min-1.g-1
Compound 4: the middle estimate sits 3.4-fold (0.53 log units) above what was measured, outside the stated range (below it).
By their numbers in this assay, from the lowest: compound 4; then compound 2; then compounds 3 and 1 (each within the scatter of the next).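

Among the compounds shown here, at this carbonyl carbon the series is clearly sensitive to a small exchange: a 6.1-fold lower number from compound 3 to compound 4 (0.78 log units; beyond the scatter), the first step here that turns on methylamino in place of methyl. Methylcarbamoyl also outdoes both larger groups on the aromatic carbon, with a 2.3-fold lower number from compound 2 to compound 4 (0.36 log units; beyond the scatter) and a 6.3-fold lower number from compound 1 to compound 4 (0.80 log units; beyond the scatter), which makes compound 4 the lowest of the four, beyond the scatter against each of the others. Nothing available accounts for the drop.

Open, going by these compounds, is whether the lower clearance persists with ethylamino or dimethylamino on the same carbonyl carbon, the latter lacking the amide hydrogen.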